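A few compounds are considered here, and "the series" means these few. Any claim that something is new, unique, unknown or untested is made for them only; others in the source may bear on it.

Three compounds have numbers in a functional assay on A549 cells (Homo sapiens) for antiproliferative activity, read by MTT assay, with a stated time of 72 h; on this read-out higher numbers stand for weaker inhibition and lower numbers for stronger inhibition:

Compound 1, `NC1=NC2(CCSCC2)N(OCCCOc2ccc(Br)cc2)C(N)=N1`: 740 nM
Compound 2, `COc1ccc(OCCCON2C(N)=NC(N)=NC23CCSCC3)cc1`: 240 nM
Compound 3, `NC1=NC2(CCSCC2)N(OCCCOc2ccccc2Cl)C(N)=N1`: 80 nM

Compound 3 gives the lowest number of the three in this assay; the nearest is a 3.0-fold lower number from compound 2 to compound 3 (0.48 log units; beyond the scatter) and the furthest is a 9.3-fold lower number from compound 1 to compound 3 (0.97 log units; beyond the scatter), both beyond the scatter. Compound 4, `NC1=NC2(CCSCC2)N(OCCCOc2cccc(Br)c2)C(N)=N1`, has not been measured. It differs from compound 3 in one place: 3-bromophenyl in place of 2-chlorophenyl on an oxygen on a saturated carbon. Going by the values given here, no measured step swaps a 2-chlorophenyl for a 3-bromophenyl, so the steps that bear on it are indirect. The step of a 9.3-fold lower number from compound 1 to compound 3 (0.97 log units; beyond the scatter) shows that a 4-bromophenyl on this oxygen gave a markedly higher number than the 2-chlorophenyl, and a 3.1-fold lower number from compound 1 to compound 2 (0.49 log units; beyond the scatter) shows that a 4-methoxyphenyl also sat well below the 4-bromophenyl. A 3-bromophenyl has not been tried, so its number cannot be placed with confidence; a modest step toward a higher number in this assay is expected, above the number of compound 3 yet below that of compound 1. Compound 4 is therefore estimated at 200 nM, within 60 nM to 700 nM, which means an expected step of a 2.5-fold higher number from compound 3 to compound 4 (0.40 log units; beyond the scatter).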

Compound 4, half-maximal inhibitory concentration: 50 nM
The estimate for compound 4 lay 4.0-fold (0.60 log units) above the measured number, outside the stated range (below it).
By their numbers in this assay, from the lowest: compounds 4 and 3 (each within the scatter of the next); then compound 2; then compound 1.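

In this assay, the 3-bromophenyl on this oxygen performs on a par with the 2-chlorophenyl, with a 1.6-fold lower number from compound 3 to compound 4 (0.20 log units; within the scatter), so a bromine on the phenyl does not by itself bring the high number of compound 1. Moving from the 4-bromophenyl to the 3-bromophenyl gives a 15-fold lower number from compound 1 to compound 4 (1.17 log units; beyond the scatter), the largest step in the set, and the 4-methoxyphenyl also stands well apart, with a 4.8-fold lower number from compound 2 to compound 4 (0.68 log units; beyond the scatter), so among these four compounds the two 4-substituted phenyl groups give the higher numbers. Nothing at hand explains why the place of the bromine matters so much.

Going by these compounds, whether a 3-methoxyphenyl or an unsubstituted phenyl would stay level with compound 4 remains open. So does whether a 3-chlorophenyl would, and whether a longer chain on this oxygen would keep such a number.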